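Selenium Alkylation on a Pyridopyrimidine Core

A few compounds are considered here, and "the series" means these few. Any claim that something is new, unique, unknown or untested is made for them only; others in the source may bear on it.

Compounds measured in a functional assay on HTB-54 cells (Homo sapiens) for cytotoxicity, read by MTT assay, with a stated time of 72 h; a higher number here means a weaker inhibitor of growth, a lower number a stronger inhibitor of growth:
compound 1 `Nc1nc([SeH])nc2ncccc12` 44300 nM
compound 2 `[SeH]c1nc([SeH])c2cccnc2n1` 4030 nM
compound 3 `COc1ccc(CNc2nc([Se]C)nc3ccccc23)cc1` 33000 nM

Compound 1 has the highest of the three numbers in this assay; compound 3 sits within the scatter of it, while compound 2 lies well apart, with an 11-fold lower number from compound 1 to compound 2 (1.04 log units; beyond the scatter). Compound 4 `CCCCC[Se]c1nc(N)c2cccnc2n1` differs from compound 1 by pentyl in place of hydrogen on a selenium. No measured step covers such a change: the only step shown is the one from compound 1 to compound 2, which concerns a different site. Compound 3 carries a methyl on its selenium, but it also differs elsewhere, so it only shows its own value. For compound 4 no step beyond the scatter is expected, so a 1.5-fold lower number from compound 1 to compound 4 (0.17 log units; within the scatter) is estimated. Compound 4 is therefore expected at 30000 nM, within 8000 nM to 100000 nM.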

Compound 4, concentration for 50% growth inhibition: 8780 nM
Compound 4: middle estimate off by 3.4-fold (0.53 log units), on the high side, and the stated range covers the measured number.
By their numbers in this assay, from the lowest: compound 2; then compound 4; then compounds 3 and 1 (each within the scatter of the next).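

Pentyl in place of hydrogen on a selenium gives a 5.0-fold lower number from compound 1 to compound 4 (0.70 log units; beyond the scatter) in this assay, the first single change shown at this selenium. This position therefore accepts a chain, and the change moves the number beyond the scatter. No evidence shown here accounts for this step.

As far as these compounds go, it remains open whether a shorter chain such as ethyl, a longer chain such as octyl, or a chain ending in an amine or a carboxylic acid would lower the number further or reverse the step.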